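Benzyl for tert-butyl on the ester of compound 3

The source may hold more compounds than are shown below. What is called first, only, known or untested is meant among the compounds shown, and "the series" means these compounds.

Three thiourea-containing esters sharing one core have been measured in an assay on membranes from HeLa cells for displacement of a labelled ligand from adenosine receptor A3 (Homo sapiens), read by scintillation counting, with a stated time of 180 min, tested at 1 uM; a lower number here means less inhibition, a higher number more inhibition at the concentration tested (going by the name of the read-out). Compound 1 `CC1=C(C(=O)OCc2ccccc2)C(c2ccoc2)NC(=S)N1` gives 20%, compound 2 `CCCOC(=O)C1=C(C)NC(=S)NC1c1cccs1` gives 10%, and compound 3 `CC1=C(C(=O)OC(C)(C)C)C(c2cccs2)NC(=S)N1` gives 22%. Compound 3 stands highest of the three: compound 1 lies within the scatter of it, while compound 2 lies beyond it, the step being a number 12 percentage points higher from compound 2 to compound 3 (beyond the scatter), a modest rise with tert-butyl in place of propyl. Compound 4 `CC1=C(C(=O)OCc2ccccc2)C(c2cccs2)NC(=S)N1` differs from compound 3 by benzyl in place of tert-butyl on an oxygen next to a carbonyl group. Going by the values given here, the only measured step at this position is the rise to compound 3; compound 1 already carries a benzyl ester and its value sits close to that of compound 3, so no step beyond the scatter is expected in this assay, an estimated a number 2 percentage points lower from compound 3 to compound 4 (within the scatter). Compound 4 is therefore expected to give about 20%, between 8% and 32%.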

Compound 4, a percentage reported as inhibition, at one concentration (the size of the read-out at that concentration, not a potency): 24%
Compound 4: middle estimate off by 4 percentage points, on the low side; low and high end bracket the measured number.
By their numbers in this assay, from the lowest: compounds 2, 1, 3 and 4 (each within the scatter of the next, the first and the last beyond it).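

In this assay, benzyl and tert-butyl on the oxygen cannot be told apart: the change gives a number 2 percentage points higher from compound 3 to compound 4 (within the scatter). Phenyl in place of ethyl on the saturated chain carbon gives a number 14 percentage points higher from compound 2 to compound 4 (beyond the scatter), so the benzyl ester, like the tert-butyl ester, stands clear of the propyl ester. With the benzyl ester held, thiophen-2-yl in place of furan-3-yl on the saturated ring carbon gives a number 4 percentage points higher from compound 1 to compound 4 (within the scatter), which is no change beyond the scatter. The compounds shown leave open how an amine on the ester chain, or a carboxylic acid in place of the ester, would read. Nothing further is available that bears on these steps.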